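Four Related Compounds Tested on a Lung Cancer Cell Line

The source may report more compounds than this note shows. Statements on the series, on what has been measured and on what is new or still open speak of the compounds shown alone.

Measured so far:
- compound 1 `O=C(/C=C/c1ccc(OCCCCO[N+](=O)[O-])c(O)c1)OCCCCO[N+](=O)[O-]`: > 50000 nM
- compound 2 `O=C(/C=C/c1ccc(OCCCCCCO[N+](=O)[O-])c(O)c1)OCCCCCCO[N+](=O)[O-]`: > 50000 nM
- compound 3 `COc1cc(/C=C/C(=O)OCCCCO[N+](=O)[O-])ccc1OCCCCO[N+](=O)[O-]`: > 50000 nM

All three compounds were tested in a functional assay on NCI-H1792 cells (Homo sapiens) for cytotoxicity, read by resazurin assay, with a stated time of 72 h; a higher number here means a weaker inhibitor, a lower number a stronger inhibitor. For compound 1 the value > 50000 nM is a limit of the assay, not a number. For compound 2 the value > 50000 nM is likewise only a limit. For compound 3 the value > 50000 nM is also a limit. Compound 3 differs from compound 1 by one change, (methyl in place of hydrogen on an oxygen on an aromatic ring), and the resulting step that the two limits leave unreadable from compound 1 to compound 3 cannot be sized, since both ends sit at the limit; this is summarised by the limit of > 50000 nM in this assay, at which 3 of the 3 values shown sit.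

Compound 2 and compound 1 share the same pattern of groups but carry different chains; the difference between the two cores is not broken down here.

The compound not yet measured is compound 4 `COc1cc(/C=C/C(=O)OCCCCCCO[N+](=O)[O-])ccc1OCCCCCCO[N+](=O)[O-]`. It stands to compound 2 as compound 3 stands to compound 1: the change is methyl in place of hydrogen on an oxygen on an aromatic ring, and since the surroundings of the place are described in the same words in both cases, it is the same change. Compound 2 already gives only a limit, and the same change left compound 3 at the limit, so compound 4 is expected to remain at the limit as well, with the expected step that the limit leaves unreadable from compound 2 to compound 4 not readable. The estimate for compound 4 is 90000 nM, between 30000 nM and 400000 nM.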

Compound 4, half-maximal inhibitory concentration: > 50000 nM
Compound 4: no number, only a limit; the forecaster's own chance of this, stated with the estimate: 85%; the middle value does not contradict the limit.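

Compound 2 and compound 4 each give only a limit, not a number, so no size can be given for the change from hydroxy to methoxy between them, because every result sits at the same limit: the limit of > 50000 nM in this assay, at which 4 of the 4 values shown sit.

The compounds shown leave open whether this change, or the different chains, alters the strength of any compound in this assay, as none of them gives a number to compare.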